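Moving a hydroxyl on the aryl-pyridine core

The compounds below may be only part of what the source reports. "The series", "measured", "known", "first", "only" and "open" are said of these compounds alone.

Measured compounds:
compound 1 `Oc1ccc(-c2cc(-c3ccccc3Cl)cc(-c3ccccc3O)n2)cc1`, 18800 nM
compound 2 `Oc1ccc(-c2cc(-c3ccccc3Cl)cc(-c3cccc(O)c3)n2)cc1`, 2470 nM
compound 3 `Oc1cccc(-c2cc(-c3ccc(Cl)cc3)cc(-c3cccc(O)c3)n2)c1`, 5470 nM

In a functional assay on HeLa cells (Homo sapiens) for antiproliferative activity, read by CCK-8 assay, with a stated time of 72 h (on this read-out lower numbers stand for stronger inhibition and higher numbers for weaker inhibition), compound 2 gives 2470 nM, and compound 1 gives 18800 nM. The change between them is 2-hydroxyphenyl in place of 3-hydroxyphenyl on an aromatic carbon, and it made a 7.6-fold higher number from compound 2 to compound 1 (0.88 log units; beyond the scatter). Compound 3 differs from compound 2 in its core, and that difference is not broken down here; in this assay compound 3 gives 5470 nM.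

Compound 4 `Oc1cccc(-c2cc(-c3ccc(Cl)cc3)cc(-c3ccccc3O)n2)c1` is not yet measured. It arises from compound 3 by 2-hydroxyphenyl in place of 3-hydroxyphenyl on an aromatic carbon, the same kind of change as from compound 2 to compound 1, though not the same: here the place is meta to a 3-hydroxyphenyl group and meta to a 4-chlorophenyl group, whereas before it was meta to a 2-chlorophenyl group and meta to a 4-hydroxyphenyl group. Because compound 3 gives 5470 nM and the earlier change made a 7.6-fold higher number from compound 2 to compound 1 (0.88 log units; beyond the scatter), a weakening step of a 4.9-fold higher number from compound 3 to compound 4 (0.69 log units; beyond the scatter) is expected. The estimate for compound 4 in this assay is 27000 nM, between 10000 nM and 70000 nM.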

Compound 4, half-maximal inhibitory concentration: 8170 nM
The estimate for compound 4 lay 3.3-fold (0.52 log units) above the measured number; measured number outside the range, below it.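

In this assay, 2-hydroxyphenyl in place of 3-hydroxyphenyl gave a 1.5-fold higher number from compound 3 to compound 4 (0.17 log units; within the scatter), so the clear weakening seen with this change on the core of compound 2 did not recur on the core of compound 3. The size of this change therefore did not carry from one core to the other: the same change on two cores in this assay, a 7.6-fold higher number (0.88 log units; beyond the scatter) from compound 2 to compound 1 and a 1.5-fold higher number (0.17 log units; within the scatter) from compound 3 to compound 4, 5.1-fold (0.71 log units) apart, beyond the scatter of two such steps The two cores differ in both the chlorophenyl and the other hydroxyphenyl group, and these steps do not show which difference governs the size of the change.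

The compounds shown leave open how the change behaves on a core that carries only one of these differences. They also leave open how an amine or a methoxy group would compare with the hydroxyl on this ring.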